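Trifluoromethylphenyl hydrazone series: moving the ring substituent

The compounds below may be only part of what the source reports. "The series", "measured", "known", "first", "only" and "open" are said of these compounds alone.

Working notes. In a functional assay on BCG823 cells (Homo sapiens) for inhibition, read by MTT assay, with a stated time of 72 h (on this read-out higher numbers stand for weaker inhibition and lower numbers for stronger inhibition), compound 3 `CN(C(=O)NC(=O)c1ccccc1F)c1nc(C(F)(F)F)c(C(=O)N/N=C/c2ccccc2C(F)(F)F)s1` gives 4.67 ug/mL. Compound 2 `CN(C(=O)NC(=O)c1ccc(F)c(F)c1)c1nc(C(F)(F)F)c(C(=O)N/N=C/c2ccccc2C(F)(F)F)s1` gives 3.66 ug/mL, and the step of a 1.3-fold higher number from compound 2 to compound 3 (0.11 log units; within the scatter) stays within the scatter. Among the measured compounds shown here, compound 1 `CN(C(=O)NC(=O)c1ccc(Cl)cc1Cl)c1nc(C(F)(F)F)c(C(=O)N/N=C/c2ccc(C(F)(F)F)cc2)s1` gives 3.08 ug/mL; no single-point step connects it to compound 3, and the two numbers are within the scatter of each other. Compound 4 `CN(C(=O)NC(=O)c1ccccc1F)c1nc(C(F)(F)F)c(C(=O)N/N=C/c2ccc(C(F)(F)F)cc2)s1` differs from compound 3 by 4-(trifluoromethyl)phenyl in place of 2-(trifluoromethyl)phenyl on a carbon with a double bond to nitrogen. For the measured compounds named here, no measured step alters this group alone; compound 1 carries the same 4-(trifluoromethyl)phenyl but differs elsewhere as well, so it offers only an indirect comparison, and its number and that of compound 3 are within the scatter. The step of a 1.2-fold lower number from compound 3 to compound 4 (0.07 log units; within the scatter) is thus expected to remain within the scatter, with no clear direction. For compound 4 the estimate is 4 ug/mL, range 2 ug/mL to 8 ug/mL.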

Compound 4, half-maximal inhibitory concentration: 3.87 ug/mL
For compound 4 the middle estimate is 1.0-fold (0.01 log units) above the measured one; low and high end bracket the measured number.
By their numbers in this assay, from the lowest: compounds 1, 2, 4 and 3 (each within the scatter of the next).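

In this assay, the series gains its first direct reading at this position: 4-(trifluoromethyl)phenyl in place of 2-(trifluoromethyl)phenyl on a carbon with a double bond to nitrogen gives a step within the scatter (a 1.2-fold lower number from compound 3 to compound 4 (0.08 log units; within the scatter)). With 4-(trifluoromethyl)phenyl held, 2-fluorophenyl in place of 2,4-dichlorophenyl on a carbonyl carbon also stays within the scatter (a 1.3-fold higher number from compound 1 to compound 4 (0.10 log units; within the scatter)). No supporting evidence bears on these results.

Open, as far as these compounds go, is whether an amine or a carboxylic acid in place of trifluoromethyl on this phenyl would give a step beyond the scatter.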